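Changing the carbonyl substituent of compound 1

A few compounds are considered here, and "the series" means these few. Any claim that something is new, unique, unknown or untested is made for them only; others in the source may bear on it.

Measured compounds:
- compound 1, `C#CCNC(=O)c1ccc(C(CC)(CC)c2ccc(OCC(O)C(C)(C)C)c(C)c2)n1CC`, 39100 nM
- compound 2, `CC[C@@H](C)[C@H](NC(=O)c1ccc(C(CC)(CC)c2ccc(OCC(=O)C(C)(C)C)c(C)c2)n1CC)C(=O)O`, 4500 nM
- compound 3, `CCn1c(C(=O)N(C)CC(=O)O)ccc1C(CC)(CC)c1ccc(OCC(=O)C(C)(C)C)c(C)c1`, 35900 nM

These three share one core and differ only in the group on the carbonyl carbon. In a functional assay on Caco-2 cells (Homo sapiens), read by MTT assay, with a stated time of 48 h (on this read-out lower numbers stand for stronger inhibition and higher numbers for weaker inhibition), compound 1 gives the highest of the three numbers; compound 3 lies within the scatter of it, while compound 2 lies well apart from both. Going by the values given here, the only single-place step among the measured compounds is an 8.0-fold higher number from compound 2 to compound 3 (0.90 log units; beyond the scatter), which shows that what sits on this carbonyl carbon can move the number by a modest amount.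

Compound 4, `CCn1c(C(=O)Oc2ccc(CCO)cc2)ccc1C(CC)(CC)c1ccc(OCC(O)C(C)(C)C)c(C)c1`, is not yet measured. It differs from compound 1 in the same position: a group of 10 heavy atoms (8 carbon, 2 oxygen; one six-membered aromatic ring of carbon only) in place of a group of 4 heavy atoms (3 carbon, 1 nitrogen; no ring), on a carbonyl carbon. Among the compounds with values here, no measured step covers an exchange of this kind, so the step from compound 2 to compound 3 is the only guide to how much the carbonyl substituent matters here, and it gives no direction. Compound 4 is therefore expected to stay near compound 1, with a step of a 1.3-fold lower number from compound 1 to compound 4 (0.12 log units; within the scatter) that may not exceed the scatter. The estimate for compound 4 in this assay is 30000 nM, between 8000 nM and 110000 nM.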

Compound 4, half-maximal inhibitory concentration: > 50000 nM
Compound 4: a limit, no number; the forecaster's own chance of this, stated with the estimate: 20%; at least 1.6-fold (0.22 log units) between middle value and limit.
By their numbers in this assay, from the lowest: compound 2; then compounds 3 and 1 (each within the scatter of the next). At a limit, above all of these: compound 4.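

Compound 4 gives no number in this assay, only a limit of the assay: the limit of > 50000 nM in this assay, at which 1 of the 4 values shown sits. From the compounds shown here alone, putting the group with the six-membered aromatic ring in place of propargylamino on this carbonyl carbon gives an at least 1.2-fold higher number from compound 1 to compound 4 (0.10 log units; that floor lies within the scatter), so the printed floor does not separate the two compounds and the true size of the step stays unknown. What this adds is a direction that the step of an 8.0-fold higher number from compound 2 to compound 3 (0.90 log units; beyond the scatter) could not give for compound 1: this larger aromatic group brings no lower number.

The compounds shown leave open how far compound 4 lies past its limit. They also leave open how a tertiary amine, a morpholine ring or a longer alkyl chain on this carbonyl carbon would read in this assay.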